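From a chloromethyl to a 1-aminoethyl group

A few compounds are considered here, and "the series" means these few. Any claim that something is new, unique, unknown or untested is made for them only; others in the source may bear on it.

So far, two compounds with a shared core have been measured. In a functional assay on SU-DHL-6 cells (Homo sapiens) for antiproliferative activity, read by MTT assay (a higher number here means a weaker inhibitor, a lower number a stronger inhibitor), compound 1 `COc1ncc(-c2ccc3ncnc(N[C@H]4CCCN(C(=O)CCBr)C4)c3c2)cc1C#N` gives 15 nM. In the same test compound 2 `COc1ncc(-c2ccc3ncnc(N[C@H]4CCCN(C(=O)CCl)C4)c3c2)cc1C#N` gives 380 nM, the higher number of the two, which makes it the weaker inhibitor. Compound 3 `COc1ncc(-c2ccc3ncnc(N[C@H]4CCCN(C(=O)C(C)N)C4)c3c2)cc1C#N` has not yet been measured. It differs from compound 2 in one place: 1-aminoethyl in place of chloromethyl on a carbonyl carbon. In words, 1-aminoethyl stands in place of chloromethyl on a carbonyl carbon. Among the compounds with values here, the only measured step that touches this part of the molecule is a 25-fold higher number from compound 1 to compound 2 (1.40 log units; beyond the scatter). That step is large, so a sizeable change is possible here too, but it involves no amine and sets no direction. A modest move towards weaker inhibition is expected, and the estimated step is a 2.4-fold higher number from compound 2 to compound 3 (0.37 log units; beyond the scatter). Compound 3 is expected to give about 900 nM in this assay, with an estimated range of 150 nM to 5000 nM.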

Compound 3, half-maximal inhibitory concentration: 440 nM
Estimate against measurement, compound 3: 2.0-fold (0.31 log units) above; the range from low to high includes it.
By their numbers in this assay, from the lowest: compound 1; then compounds 2 and 3 (each within the scatter of the next).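

In this assay, putting 1-aminoethyl in place of chloromethyl on the carbonyl carbon gives a 1.2-fold higher number from compound 2 to compound 3 (0.06 log units; within the scatter), so two groups with different atoms, one holding chlorine and the other nitrogen, cannot be told apart at this position by this read-out. The 2-bromoethyl group stays apart from both, since changing it to 1-aminoethyl gives a 29-fold higher number from compound 1 to compound 3 (1.47 log units; beyond the scatter), which shows that the large gap seen earlier also holds for a group bearing an amine. These numbers alone cannot say what sets 2-bromoethyl apart, and no other data on these compounds bear on the question.

Still open, as far as these compounds go, is whether 2-chloroethyl would read like the bromine compound or like the chloromethyl one, which would help separate the effect of the halogen from that of the chain. Also open, from the compounds shown here alone, is how aminomethyl, a longer chain ending in an amine, or a carboxylic acid would read at this position.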